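Aryl in place of methyl on the ring amide nitrogen

The source may hold more compounds than are shown below. What is called first, only, known or untested is meant among the compounds shown, and "the series" means these compounds.

Measured so far:
- compound 1 `CC(C)[C@@H]1CC[C@@H](C)C[C@@]12N(C)C(=O)[C@@H]1[C@H]3C(=O)N(C)C(=O)[C@H]3ON12`: 75.3%
- compound 2 `CC(C)[C@@H]1CC[C@@H](C)C[C@@]12N(C)C(=O)[C@@H]1[C@H]3C(=O)N(c4ccc(Cl)cc4)C(=O)[C@H]3ON12`: 74%

In a functional assay, read by spectrophotometry, with a stated time of 2 h, tested at 3 mg/mL (a lower number here means a weaker effect, a higher number a stronger effect of the compound at the concentration tested), compound 1 gives 75.3% and stands highest of the two numbers, with compound 2 nearest at 74%; the two lie within the scatter of each other. Among the measured compounds shown here, the one measured step, a number 1.3 percentage points lower from compound 1 to compound 2 (within the scatter), swaps methyl for 4-chlorophenyl on the amide-type nitrogen in a ring and changes nothing beyond the scatter.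

Compound 3 `COc1ccc(N2C(=O)[C@H]3[C@H](ON4[C@@H]3C(=O)N(C)[C@@]43C[C@H](C)CC[C@H]3C(C)C)C2=O)cc1` is not yet measured. It differs from compound 1 as 4-methoxyphenyl in place of methyl on an amide-type nitrogen in a ring. The step from compound 1 to compound 2 bears directly on this change, since it also places a 4-substituted phenyl at the same amide-type nitrogen in a ring, and it was within the scatter. No step beyond the scatter is therefore expected in this assay for compound 3. Compound 3 is estimated at 74%, between 64% and 84%. The expected step is a number 1.3 percentage points lower from compound 1 to compound 3 (within the scatter), within the scatter.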

Compound 3, a percentage reported as activity, at one concentration (the size of the read-out at that concentration, not a potency): 75.1%
Compound 3: the middle estimate sits 1.1 percentage points below what was measured; the range from low to high includes it.
By their numbers in this assay, from the lowest: compounds 2, 3 and 1 (each within the scatter of the next).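

In this assay, a second 4-substituted phenyl on the amide-type nitrogen in a ring again leaves the read-out within the scatter of the methyl compound (a number 0.2 percentage points lower from compound 1 to compound 3 (within the scatter)), so this result is not confined to 4-chlorophenyl. Methoxy in place of chloro on the aromatic carbon also stays within the scatter (a number 1.1 percentage points higher from compound 2 to compound 3 (within the scatter)), and this read-out does not separate the two aryl groups. Nothing available explains why these changes at this nitrogen leave the read-out in place.

From the compounds shown here alone, whether a carboxylic acid or an amine on the phenyl ring, or a longer alkyl chain in place of the aryl group, would move the read-out at this nitrogen remains open. Going by these compounds, all three compounds were read at one concentration, so any difference in potency among them also remains open.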